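Swapping 4-fluorobenzyl for 1-(ethoxycarbonyl)ethyl

The source may report more compounds than this note shows. Statements on the series, on what has been measured and on what is new or still open speak of the compounds shown alone.

For the measured compounds named here, in a functional assay on MCF7 cells (Homo sapiens) for inhibition, read by sulforhodamine B assay, with a stated time of 48 h (on this read-out lower numbers stand for stronger inhibition and higher numbers for weaker inhibition), compound 2 `COc1ccc(C(O)(Cc2ccc(F)cc2)c2cccc3ccccc23)c(OC)c1OC` gives 7560 nM, the only exact number so far. Compound 1 `C=CCC(O)(c1ccc(OC)c(OC)c1OC)c1cccc2ccccc12` reads > 20000 nM, which is a limit. Compound 3 `COc1cc(COC(c2ccc(OC)c(OC)c2OC)c2cccc3ccccc23)cc(OC)c1` reads > 20000 nM, also a limit. Compound 4 `CCOC(=O)C(C)C(O)(c1ccc(OC)c(OC)c1OC)c1cccc2ccccc12` is still unmeasured: it has 1-(ethoxycarbonyl)ethyl in place of 4-fluorobenzyl on a saturated chain carbon bound to two aromatic carbons and an oxygen on a saturated carbon. Going by the values given here, the one measured step that bears on this is an at least 2.6-fold lower number from compound 1 to compound 2 (0.42 log units; beyond the scatter), which brought in 4-fluorophenyl in place of vinyl. Compound 4 gives that ring up again, so a modest step towards weaker inhibition is expected in this assay, and a reading at the limit of > 20000 nM in this assay, at which 2 of the 3 values shown sit, is possible. The estimated step is a 2.1-fold higher number from compound 2 to compound 4 (0.33 log units; beyond the scatter). For compound 4 the expected value is 16000 nM, with an estimated range of 7000 nM to 40000 nM.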

Compound 4, half-maximal inhibitory concentration: > 20000 nM
Compound 4: only a limit was reported (the forecaster's own chance of this, stated with the estimate: 55%); at least 1.2-fold (0.09 log units) between middle value and limit.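

In this assay there is an at least 2.6-fold higher number from compound 2 to compound 4 (0.42 log units; beyond the scatter), so 1-(ethoxycarbonyl)ethyl does not keep the reading that 4-fluorobenzyl gave on this saturated chain carbon. The ester side chain, with no ring, joins allyl in giving only a limit, and the step between the limits of compound 1 and compound 4 cannot be read. Compound 2 remains the only compound with an exact number: the limit of > 20000 nM in this assay, at which 3 of the 4 values shown sit.

The compounds shown leave open whether the ring alone is enough, as plain benzyl would test. They also leave open how an amine or a carboxylic acid would read at this place.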